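This account rests on a few compounds, and the source may have more. Where it says the series, first, only, none or still open, it means among the compounds named here.

Compound 1, `O=C(NO)c1ccc(/C=C/c2ccnc(-c3ccc(C(F)(F)F)cc3)c2)cc1`: in a functional assay on MGC-803 cells (Homo sapiens) for antiproliferative activity, read by CellTiter-Glo, with a stated time of 72 h (a lower number here means a stronger inhibitor, a higher number a weaker inhibitor), compound 1 gives > 10000 nM, which is a limit of the assay rather than a number.
Compound 2, `O=C(NO)c1ccc(/C=C/c2cc(-c3ccc(C(F)(F)F)cc3)ncc2F)cc1`: in this assay compound 2 gives > 10000 nM, again a limit.
Compound 3, `Cc1ccc(-c2cncc(/C=C/c3ccc(C(=O)NO)cc3)c2)cc1`: in this assay compound 3 gives > 10000 nM, also a limit.

All three measured compounds share the hydroxamic acid and the vinyl linker but sit at the same boundary, where (the limit of > 10000 nM in this assay, at which 3 of the 3 values shown sit). Compound 1 and compound 2 differ by fluoro in place of hydrogen on an aromatic carbon. The resulting step that the two limits leave unreadable from compound 1 to compound 2 cannot be sized, since both ends are limits. The difference between the core of compound 1 and the core of compound 3 is not broken down here.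

Compound 4, `Cc1ccc(-c2cncc(/C=C/c3ccc(C(=O)NO)cc3)c2)c(F)c1`, has not yet been measured in this assay. It differs from compound 3 by fluoro in place of hydrogen on an aromatic carbon. For the measured compounds named here, this is the same kind of change as the one from compound 1 to compound 2, but the surroundings are not identical: in compound 2 the fluoro sits on a six-membered aromatic ring with 1 nitrogen, two atoms from the ring nitrogen and para to a large group, whereas in compound 4 it sits on a six-membered aromatic ring of carbon only, meta to a methyl group.

Going by the values given here, because compound 3 gives only a limit, > 10000 nM, and because the one earlier fluoro step, a step that the two limits leave unreadable from compound 1 to compound 2, moved nothing out of the limit, compound 4 is expected to remain at the boundary as well, with an expected step that the limit leaves unreadable from compound 3 to compound 4. The estimate for compound 4 is 15000 nM, expected to lie between 5000 nM and 50000 nM.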

Compound 4, half-maximal inhibitory concentration: 2240 nM
Estimate against measurement, compound 4: 6.7-fold (0.83 log units) above; measured number outside the range, below it.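

In this assay, fluoro in place of hydrogen on an aromatic carbon gives an at least 4.4-fold lower number from compound 3 to compound 4 (0.64 log units; beyond the scatter), so on the core of compound 3 this change, placed ortho to a large group and meta to a methyl group, brings the compound to a readable number. For the compounds shown here, the same kind of change on the core of compound 1 leaves compound 2 at a limit of the assay, so the earlier step cannot be read and the series offers no second sized example, with most of the values shown resting at the boundary: the limit of > 10000 nM in this assay, at which 3 of the 4 values shown sit. The result therefore shows that a single fluoro can count on one core, but not that the gain carries from one core to another, since the two fluoro atoms sit on different rings in different surroundings, and the true size of the new step remains open beyond its printed bound.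

The compounds shown leave open whether fluoro on the carbon-only ring of the core of compound 1, the ring bearing the trifluoromethyl group, would move that compound off the limit. They also leave open whether chloro, methoxy or an amine at the place taken by fluoro in compound 4 would give a step of like size.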